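A few compounds are considered here, and "the series" means these few. Any claim that something is new, unique, unknown or untested is made for them only; others in the source may bear on it.

Measured so far in a functional assay on AS49-RAW cells (Homo sapiens) for antiproliferative activity, read by sulforhodamine B assay, with a stated time of 48 h; on this read-out lower numbers stand for stronger inhibition and higher numbers for weaker inhibition:

Compound 1 `O=C(Nc1ccccc1)Nc1ccc(S(=O)(=O)Nc2ccnc3cc(C(F)(F)F)ccc23)cc1` gives 24500 nM.
Compound 2 `N=C(N)NS(=O)(=O)c1ccc(N/C(S)=N\c2ccnc3cc(C(F)(F)F)ccc23)cc1` gives 23900 nM.
Compound 3 `O=S(=O)(Nc1ccccn1)c1ccc(N/C(S)=N\c2ccnc3cc(C(F)(F)F)ccc23)cc1` gives 33500 nM.

The three numbers lie within the scatter of one another: the step of a 1.4-fold higher number from compound 2 to compound 3 (0.15 log units; within the scatter) does not exceed it, and the value of compound 1 sits within the scatter of compound 2, so no ordering among the three is claimed.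

Compound 4 `O=S(=O)(Nc1ncccn1)c1ccc(N/C(S)=N\c2ccnc3cc(C(F)(F)F)ccc23)cc1` is the next member; relative to compound 2 the change is a group of 6 heavy atoms (4 carbon, 2 nitrogen; one six-membered aromatic ring with 2 hetero atoms) in place of a group of 3 heavy atoms (1 carbon, 2 nitrogen; no ring), on a sulfonamide nitrogen. Within the data shown here, one measured step bears directly on it, the replacement at the same sulfonamide nitrogen that turns compound 2 into compound 3, which gave a 1.4-fold higher number from compound 2 to compound 3 (0.15 log units; within the scatter). The entering ring in compound 4 is a six-membered aromatic ring with 2 hetero atoms rather than 1, a closely analogous exchange at the same place. On this basis no step beyond the scatter is expected in this assay in either direction.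

Compound 4 is therefore expected to give about 28000 nM in this assay, with a range of 13000 nM to 60000 nM, corresponding to an expected step of a 1.2-fold higher number from compound 2 to compound 4 (0.07 log units; within the scatter).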

Compound 4, half-maximal inhibitory concentration: 37800 nM
Beside the measured number, compound 4's estimate is 1.4-fold (0.13 log units) below it; the range from low to high includes it.
By their numbers in this assay, from the lowest: compounds 2, 1, 3 and 4 (each within the scatter of the next).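

In this assay, the pyrimidin-2-yl group on the sulfonamide nitrogen cannot be told apart from either group compared with it: a 1.6-fold higher number from compound 2 to compound 4 (0.20 log units; within the scatter), and a 1.1-fold higher number from compound 3 to compound 4 (0.05 log units; within the scatter). Compound 2, compound 3 and compound 4 therefore show no separation at this position, whether it carries the open group with no ring or an aromatic ring with one or two hetero atoms. No data on hand bear on why this position gives no readable difference.

On these data alone, it remains open whether any group on this nitrogen can produce a step beyond the scatter, for example thiazol-2-yl, a methyl or a chain ending in a carboxylic acid. Also open, as far as these compounds go, is what chlorine in place of the trifluoromethyl on the shared core would do.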